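Halogen swap on the aryl ring of compound 1

The source may hold more compounds than are shown below. What is called first, only, known or untested is meant among the compounds shown, and "the series" means these compounds.

Measured compounds in an assay on isolated protein for inhibition of Alpha glucosidase (Homo sapiens), with stated times of 5 min and 15 min, tested at 50 uM; on this read-out higher numbers stand for more inhibition at the one concentration tested (going by the name of the read-out) and lower numbers for less inhibition:
- compound 1 `O=C1/C(=C/c2ccccc2)CCC/C1=C\c1ccccc1Cl`: 43%
- compound 2 `O=C1/C(=C/c2ccccc2)CCC/C1=C\c1cccc(Cl)c1Cl`: 44%
- compound 3 `O=C(C1=C(O)/C(=C/c2ccc(O)cc2)CCC1)c1ccccc1`: 34.9%

Compound 1 stands second highest of the three numbers. Its nearest neighbour is compound 2, where the step of a number 1 percentage points higher from compound 1 to compound 2 (within the scatter) is within the scatter; the furthest is compound 3, whose number is lower than that of compound 1, yet still within the scatter. The three values therefore cannot be ordered.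

The next compound is compound 4 `O=C1/C(=C/c2ccccc2)CCC/C1=C\c1ccccc1F`. From compound 1 it differs by fluoro in place of chloro on an aromatic carbon, on an aromatic carbon of a six-membered aromatic ring of carbon only, ortho to a large group. Among the compounds with values here, the only measured step on that ring, a number 1 percentage points higher from compound 1 to compound 2 (within the scatter), is a halogen change and stayed within the scatter. Within the data shown here, no measured step bears directly on fluoro in place of chloro. The expectation is thus a step of a number 3 percentage points lower from compound 1 to compound 4 (within the scatter) in this assay that stays within the scatter, with no direction favoured. Compound 4 is estimated at 40%, within the range 28% to 52%.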

Compound 4, a percentage reported as inhibition, at one concentration (the size of the read-out at that concentration, not a potency): 43%
Compound 4: middle estimate off by 3 percentage points, on the low side, within the range that was stated.
By their numbers in this assay, from the lowest: compounds 3, 1, 4 and 2 (each within the scatter of the next).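

In this assay, the change from 2-chlorophenyl to 2-fluorophenyl gives no change at the digits printed from compound 1 to compound 4 (within the scatter). Within the data shown here, this adds a second single change on this ring (after a number 1 percentage points higher from compound 1 to compound 2 (within the scatter)) that stays within the scatter, and it is the first to exchange the halogen itself on an aromatic carbon ortho to a large group, rather than add one. No available evidence accounts for this result.

Going by these compounds, what number groups other than halogens would give at this position remains open, as a methoxy group, an amine or a carboxylic acid in place of the chloro of compound 1 could give a different read-out. With one tested concentration, the data also leave open whether compound 1 and compound 4 would match in potency.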